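The source may hold more compounds than are shown below. What is called first, only, known or untested is meant among the compounds shown, and "the series" means these compounds.

Measured in a functional assay on HepG2 cells (Homo sapiens) for antiproliferative activity, read by MTT assay, with a stated time of 72 h; on this read-out lower numbers stand for stronger inhibition and higher numbers for weaker inhibition:
- compound 1 `O=C1COc2ccc(-c3cnc4ccccc4c3)cc2N1C1CCCCC1`: > 40000 nM (a limit)
- compound 2 `O=C1COc2ccc(-c3cnc4ccccc4c3)cc2N1`: 26300 nM

Among the measured compounds shown here, compound 2, at 26300 nM, holds the only actual number in this assay. Compound 3 `O=C1COc2ccc(-c3cnc4ccccc4c3)cc2N1c1ccccc1` puts phenyl in place of hydrogen on the amide-type nitrogen in a ring: phenyl in place of hydrogen on an amide-type nitrogen in a ring. For the measured compounds named here, the one measured step at this nitrogen is an at least 1.5-fold lower number from compound 1 to compound 2 (0.18 log units; that floor lies within the scatter). That step gives a floor and no true size. In this assay, the expectation is therefore a small move towards weaker inhibition, hardly beyond the scatter. The expected step is a 1.2-fold higher number from compound 2 to compound 3 (0.09 log units; within the scatter). For compound 3 the estimate is 32000 nM, with an expected range of 14000 nM to 70000 nM.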

Compound 3, half-maximal inhibitory concentration: > 40000 nM
Compound 3 was reported as a limit; the forecaster's own chance of this, stated with the estimate: 40%; at least 1.2-fold (0.09 log units) between middle value and limit.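

Phenyl on the amide-type nitrogen in this assay gives an at least 1.5-fold higher number from compound 2 to compound 3 (0.18 log units; that floor lies within the scatter), so an aromatic ring at this position behaves as cyclohexyl does, with no step beyond the scatter in either case. Compound 3 is reported as a limit, and the step between compound 1 and compound 3 cannot be read. Both substituted compounds end at the same limit: the limit of > 40000 nM in this assay, at which 2 of the 3 values shown sit.

On these data alone, whether methyl or a short chain carrying an amine on this nitrogen would give a lower number than compound 2 remains open. As far as these compounds go, the effect of changes elsewhere on the shared core also remains open.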